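The source may report more compounds than this note shows. Statements on the series, on what has been measured and on what is new or still open speak of the compounds shown alone.

Measured in an ADME assay on microsomes from liver (Mus musculus) for metabolic stability, with a stated time of 10 min, tested at 0.5 uM; on this read-out lower numbers stand for a less stable compound and higher numbers for a more stable compound:
Compound 1 `C[C@@H](NCc1ccc(Cl)cc1)[C@H]1CC[C@@H](c2ccnc3ccc(F)cc32)CC1`: 2%
Compound 2 `C[C@@H](NS(=O)(=O)c1ccc(Cl)cc1)[C@H]1CC[C@@H](c2ccnc3ccc(F)cc32)CC1`: < 1%, a limit of the assay and not a number
Compound 3 `C[C@@H](NC(=O)Nc1ccc(Cl)cc1)[C@H]1CC[C@@H](c2ccnc3ccc(F)cc32)CC1`: 14%

Compound 3 holds the highest value of the set at 14%. The measured steps to it are a number 12 percentage points higher from compound 1 to compound 3 (beyond the scatter) and a number at least 13 percentage points higher from compound 2 to compound 3 (beyond the scatter). Compound 4 `C[C@@H](NC(=O)c1cccc(Cl)c1)[C@H]1CC[C@@H](c2ccnc3ccc(F)cc32)CC1` keeps the shared core and the carbonyl but carries 3-chlorophenyl in place of (4-chlorophenyl)amino on a carbonyl carbon. For the measured compounds named here, no measured step makes this exact change. The nearest evidence comes from the two steps into compound 3, both of which replace the group on the same amine nitrogen, and the step of a number at least 1 percentage points lower from compound 1 to compound 2 (that floor lies within the scatter) adds little. Those steps suggest that compound 3 is the exception in a low-lying set, so a somewhat lower number is expected in this assay, though not a drop beyond the scatter. The estimated step is a number 5 percentage points lower from compound 3 to compound 4 (within the scatter). For compound 4 the expected value is 9%, within an estimated range of 2% to 25%.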

Compound 4, percent of the compound remaining: 9%
Compound 4: the middle estimate sits on the measured number at the digits printed; measured number inside the range.
By their numbers in this assay, from the lowest: compounds 1, 4 and 3 (each within the scatter of the next, the first and the last beyond it). At a limit, below all of these: compound 2.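

Replacing (4-chlorophenyl)amino with 3-chlorophenyl on the carbonyl carbon gives a number 5 percentage points lower from compound 3 to compound 4 (within the scatter), so in this assay this pair does not show that the hydrogen-bond donor counted in the leaving group is needed to hold the value of compound 3. On the amine nitrogen, (3-chlorophenyl)carbonyl in place of 4-chlorobenzyl gives a number 7 percentage points higher from compound 1 to compound 4 (within the scatter), which leaves compound 4 separated from neither compound 1 nor compound 3. Compound 2 gives a limit of the assay and not a number, so a number at least 8 percentage points higher from compound 2 to compound 4 (that floor lies within the scatter) is only a floor: the limit of < 1% in this assay, at which 1 of the 4 values shown sits.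

From the compounds shown here alone, this change alters the linking atom and the chlorine's place on the ring together, so the share of each remains open. Going by these compounds, it is also open whether a pyridine ring or a carboxylic acid on the carbonyl carbon's aromatic group would give a number beyond the scatter of compound 3.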